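Swapping an amide-bearing chain for a branched alkyl one

The source may report more compounds than this note shows. Statements on the series, on what has been measured and on what is new or still open speak of the compounds shown alone.

Compound 2 `NC(=O)CC[C@H](NC(=O)CN(c1nc(Cl)nc2[nH]cnc12)C1CC1)C(=O)OCc1ccccc1` carries a 2-carbamoylethyl group on the saturated chain carbon that links an amide-type nitrogen and a carbonyl carbon. In a functional assay on the whole organism (Tail, strain ICR) with Mus musculus as the target, in the tail flick test, with a stated time of 150 min, at a dose of 25 umol/kg by the oral route (a higher number here means a stronger effect of the compound at the dose given, a lower number a weaker effect), compound 2 gives 31.1%, the higher of the two numbers measured. Compound 1 `O=C(CN(c1nc(Cl)nc2[nH]cnc12)C1CC1)NCC(=O)OCc1ccccc1`, which has only hydrogen at that position, gives 18% in this assay. Among the measured compounds shown here, the single known step, a number 13.1 percentage points higher from compound 1 to compound 2 (beyond the scatter), shows that building this side chain out from hydrogen raised the read-out.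

Compound 3 `CC(C)C[C@H](NC(=O)CN(c1nc(Cl)nc2[nH]cnc12)C1CC1)C(=O)OCc1ccccc1` changes the side chain differently: isopropyl in place of carbamoylmethyl on a saturated chain carbon, two bonds along the chain from an amide-type nitrogen and a carbonyl carbon. The amide part of the chain leaves and a branched carbon group enters, so what remains is isobutyl rather than 2-carbamoylethyl. For the measured compounds named here, no measured step tests the removal of the amide while a chain is kept, and the one known step only shows that a chain is better than none. The expectation for compound 3 is therefore a step of a number 5.1 percentage points lower from compound 2 to compound 3 (within the scatter), within the scatter and of uncertain direction. Compound 3 is estimated to give 26%, with a range from 10% to 45%.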

Compound 3, a percentage reported as activity, at one dose (the size of the read-out at that dose, not a potency): 5.26%
For compound 3 the middle estimate is 20.7 percentage points above the measured one; measured number outside the range, below it.
By their numbers in this assay, from the lowest: compound 3; then compound 1; then compound 2.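

In this assay, the change from 2-carbamoylethyl to isobutyl gives a number 25.8 percentage points lower from compound 2 to compound 3 (beyond the scatter), so the read-out at this position depends on what the side chain carries and not merely on a chain being present. Among the compounds shown here, the comparison with hydrogen points the same way: a number 12.7 percentage points lower from compound 1 to compound 3 (beyond the scatter) shows that isobutyl falls below plain hydrogen, whereas 2-carbamoylethyl rose above it, so building out from hydrogen can move this read-out in either direction, which the single earlier step could not reveal. No measurement available here accounts for this difference between the two chains.

The compounds shown leave open whether the amide itself matters or whether other groups on a similar chain would do as well, and a carboxylic acid or an amine in place of the amide, or a longer chain still ending in the amide, would address that. An unbranched butyl chain would likewise show whether the drop seen with isobutyl goes with the branching or with having only carbon atoms in the chain.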